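The source may hold more compounds than are shown below. What is called first, only, known or untested is meant among the compounds shown, and "the series" means these compounds.

Of the compounds shown here, three that share one core have been tested in a functional assay on NCI-H226 cells (Homo sapiens) for inhibition, read by sulforhodamine B assay, with a stated time of 48 h; a lower number here means a stronger inhibitor of growth, a higher number a weaker inhibitor of growth. Compound 1 `CC1CCCc2c1nc(N)c(C#N)c2-c1cccn1C` gives 64600 nM in this assay, and compound 3 `Cn1cccc1-c1cc(-c2cccs2)[nH]c(=O)c1C#N` gives 69200 nM. For compound 2 `Cn1cccc1-c1cc(-c2cccs2)nc(N)c1C#N` this assay reports only a limit, > 100000 nM, so compound 2 stands at the edge of what the measurement can report, namely (the limit of > 100000 nM in this assay, at which 1 of the 3 values shown sits). Compound 4 `Cn1cccc1-c1cc(-c2ccccc2)nc(N)c1C#N` differs from compound 2 by phenyl in place of thiophen-2-yl on an aromatic carbon. For the measured compounds named here, no step between measured compounds is available to show how large such a change tends to be in this assay. The step of a number no higher from compound 2 to compound 4 (the limit leaves the size open) is therefore expected to stay within the usual scatter, with a real chance that only a limit is reported again. Compound 4 is estimated at 100000 nM, within a range from 40000 nM to 250000 nM.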

Compound 4, concentration for 50% growth inhibition: > 100000 nM
Compound 4: no number, only a limit (the forecaster's own chance of this, stated with the estimate: 55%); the middle value sits exactly at the limit.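

Compound 2 and compound 4 both give only a limit rather than a number, so no step between them can be read: the limit of > 100000 nM in this assay, at which 2 of the 4 values shown sit.

The compounds shown leave open how phenyl and thiophen-2-yl compare on this core.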